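This account rests on a few compounds, and the source may have more. Where it says the series, first, only, none or still open, it means among the compounds named here.

Working notes on the series, read in a functional assay on the whole organism (strain Icem-CET (SPF Caw)) for inhibition, with Mus musculus as the target, with a stated time of 30 min; on this read-out lower numbers stand for an effect already at smaller amounts and higher numbers for an effect only at larger amounts of compound.

Compound 1 `C/C(C(=O)NC1CC1)=C(/C)c1ccc(Br)cc1` gives 8.2 mg/kg. Compound 2 `C/C(C(=O)NC1CC1)=C(/C)c1ccc(Cl)cc1` gives 11.4 mg/kg; the step of a 1.4-fold higher number from compound 1 to compound 2 (0.14 log units; within the scatter) is within the scatter, so the two cannot be told apart on these numbers. Compound 3 `C/C(C(=O)NC1CC1)=C(\C)c1ccc(Br)cc1` gives 52.4 mg/kg; the step of a 6.4-fold higher number from compound 1 to compound 3 (0.81 log units; beyond the scatter) is beyond the scatter, and it rests on (the fact that compounds 1 and 3 differ only in the configuration as drawn). Compound 1 thus stands with compound 2 at one end of the three numbers and is separated only from compound 3.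

Compound 4 `C#CCNC(=O)/C(C)=C(\C)c1ccc(Br)cc1` is not yet measured. Relative to compound 1 the change is propargyl in place of cyclopropyl on an amide-type nitrogen. Neither measured step bears directly on this change: the step from compound 1 to compound 2 concerns the halogen on the aromatic ring, and the step from compound 1 to compound 3 concerns only the configuration of the double bond. Both the aromatic bromo and the drawn configuration of compound 1 are kept in compound 4; only the group on the amide-type nitrogen is exchanged. Among the measured compounds shown here, with no measured step on this part of the molecule, no step beyond the scatter is expected in either direction. Compound 4 is therefore estimated at 11 mg/kg, with a range from 5 mg/kg to 28 mg/kg. The estimate means an expected step of a 1.3-fold higher number from compound 1 to compound 4 (0.13 log units; within the scatter) that stays within the scatter.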

Compound 4, dose for half-maximal effect: 18.4 mg/kg
Compound 4: middle estimate off by 1.7-fold (0.22 log units), on the low side; measured number inside the range.
By their numbers in this assay, from the lowest: compounds 1, 2 and 4 (each within the scatter of the next, the first and the last beyond it); then compound 3.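

In this assay, among the compounds shown here, the exchange on the amide-type nitrogen gives a 2.2-fold higher number from compound 1 to compound 4 (0.35 log units; beyond the scatter) and is the first reading on this part of the molecule, since the earlier steps concerned only the halogen on the aromatic ring and the configuration of the double bond. Cyclopropyl and propargyl carry the same count of heavy atoms, all carbon, and neither carries a hydrogen-bond donor or acceptor, so the read-out at this position moves modestly on a change that replaces a three-membered ring with an open group holding a triple bond. Nothing at hand bears on the cause of this step.

On these data alone, whether the loss of the ring or the presence of the triple bond matters more stays open, and so does the response of this position to a simple ethyl or longer alkyl chain, a hydroxyethyl group or an aminoethyl group. As far as these compounds go, it is also open whether the same exchange gives a similar step with chloro on the aromatic ring or with the opposite configuration at the double bond.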